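The source may hold more compounds than are shown below. What is called first, only, known or untested is meant among the compounds shown, and "the series" means these compounds.

Three compounds built on closely related cores were tested in an ADME assay on MDBK cells (Bos taurus) for cytotoxicity, read by MTT assay, with a stated time of 96 h; a higher number here means that more compound is tolerated, a lower number that less compound is tolerated. Compound 3 `c1ccc(/N=N/N2CCCC2)cc1` gives > 100000 nM in this assay, and this is a limit of the assay rather than a number. Compound 1 `Clc1cccc(/N=N/N2CCCC2)c1` differs from compound 3 by chloro in place of hydrogen on an aromatic carbon. In this assay compound 1 gives > 100000 nM, again a limit. The step that the two limits leave unreadable from compound 3 to compound 1 therefore cannot be read, because the limit of > 100000 nM in this assay, at which 3 of the 3 values shown sit, applies to both of its compounds. Compound 2 `c1ccc(/N=N/N2CCCCC2)cc1` shares much with compound 3, but the difference between the two cores is not broken down here. In this assay compound 2 gives > 100000 nM, once more a limit.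

Compound 4 `Clc1ccc(/N=N/N2CCCCC2)cc1` has not yet been measured. It differs from compound 2 by chloro in place of hydrogen on an aromatic carbon. Going by the values given here, this is the same kind of change as the one from compound 3 to compound 1, though the place is not identical: in compound 1 the chloro sits meta to a group of 7 heavy atoms, while in compound 4 it sits para to a group of 8 heavy atoms. The expected step that the limit leaves unreadable from compound 2 to compound 4 is small, which rests on compound 2 sitting at > 100000 nM and on the step that the two limits leave unreadable from compound 3 to compound 1 showing no readable effect of the same kind of change. For compound 4 the expected value is 150000 nM, estimated to lie between 80000 nM and 300000 nM, most likely again reported only as a limit.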

Compound 4, half-maximal cytotoxic concentration: > 100000 nM
Compound 4 was reported as a limit (the forecaster's own chance of this, stated with the estimate: 85%); the middle value is on the limit's open side.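

No new step can be read between compound 2 and compound 4 in this assay, because both compounds are reported only as a limit rather than a number: the limit of > 100000 nM in this assay, at which 4 of the 4 values shown sit.

The compounds shown leave open what concentration of any of them would reach the half-maximal cytotoxic effect, and whether chloro in place of hydrogen on an aromatic carbon changes that concentration at all.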